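Nitro in place of chloro: compound 3 to compound 4

A few compounds are considered here, and "the series" means these few. Any claim that something is new, unique, unknown or untested is made for them only; others in the source may bear on it.

- compound 1 `O=C(CCCCC1CCSS1)Nc1cccc(C(F)(F)F)c1` gives 80%
- compound 2 `O=C(CCCCC1CCSS1)Nc1ccc(Cl)cn1` gives 74.5%
- compound 3 `O=C(CCCCC(S)CCS)Nc1ccc(Cl)cc1` gives 44.1%

These values come from a functional assay on KB cells (Homo sapiens) for inhibition, read by MTT assay, with a stated time of 24 h, tested at 100 ug/mL; a lower number here means less inhibition of growth, a higher number more inhibition of growth at the concentration tested. Compound 3 stands lowest of the three, beyond the scatter from both compound 2 and compound 1. Compound 4 `O=C(CCCCC(S)CCS)Nc1ccc([N+](=O)[O-])cc1` differs from compound 3 by one change, nitro in place of chloro on an aromatic carbon. Among the measured compounds shown here, no measured pair differs in one place only, so the data give no direct guide to this change. No step beyond the scatter is expected, and the estimate is a number 1.9 percentage points higher from compound 3 to compound 4 (within the scatter) (a small upward move at most). The estimated value for compound 4 is 46% (expected range 30% to 62%).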

Compound 4, percent growth inhibition at one concentration: 41.1%
For compound 4 the middle estimate is 4.9 percentage points above the measured one, within the range that was stated.
By their numbers in this assay, from the lowest: compounds 4 and 3 (each within the scatter of the next); then compounds 2 and 1 (each within the scatter of the next).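

Nitro in place of chloro gives a number 3 percentage points lower from compound 3 to compound 4 (within the scatter) in this assay, the first single-place comparison in the series. On this aromatic carbon, para to a large group, the two groups are not told apart, even though nitro brings 3 heavy atoms against 1 and 2 hydrogen-bond acceptors against 0. No available measurement bears on this result.

Open, on these data alone, is whether an amine or a carboxylic acid on this carbon would also stay within the scatter of compound 3. Also open, as far as these compounds go, is whether the same change would give a similar step on the core of compound 1.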